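This account rests on a few compounds, and the source may have more. Where it says the series, first, only, none or still open, it means among the compounds named here.

Measured in an ADME assay on cells (Peritoneal macrophage cell, Mus musculus) for cytotoxicity; on this read-out lower numbers stand for stronger inhibition and higher numbers for weaker inhibition:
Compound 1 `O=C(Cn1cnc([N+](=O)[O-])n1)Nc1ccc(Oc2ccc(Cl)cc2)cc1`: 80000 nM
Compound 2 `O=C(Cn1ccnc1[N+](=O)[O-])Nc1ccc(Oc2ccccc2)cc1`: > 89000 nM (a limit, not a number)

Compound 2 stands at the limit of > 89000 nM in this assay, at which 1 of the 2 values shown sits. It therefore gives no exact starting point for the next comparison.

Compound 3 `O=C(Cn1ccnc1[N+](=O)[O-])Nc1ccc(Oc2ccc(Cl)cc2)cc1` has not yet been measured. It is compound 2 with chloro in place of hydrogen on an aromatic carbon, para to a large group, so that phenoxy becomes 4-chlorophenoxy (chloro in place of hydrogen on an aromatic carbon).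

Going by the values given here, no measured pair isolates this change. The 4-chlorophenoxy group is also carried by compound 1, which differs from compound 3 elsewhere. Among the compounds with values here, compound 1 gives 80000 nM, and this is the only guide to the likely size of the step. A small move toward lower numbers is therefore expected, possibly none beyond the scatter, with an estimated at least 1.2-fold lower number from compound 2 to compound 3 (0.10 log units; that floor lies within the scatter).

For compound 3 the expected value is 70000 nM, with an estimated range from 30000 nM to 130000 nM.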

Compound 3, half-maximal inhibitory concentration: > 81000 nM
Compound 3 was reported as a limit (the forecaster's own chance of this, stated with the estimate: 35%); at least 1.1-fold (0.06 log units) between middle value and limit.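

In this assay compound 3 is reported at > 81000 nM, which is a limit and not a number, so adding chloro to the phenoxy group did not yield a measured value here. Compound 2 is also a limit, at > 89000 nM, and the step for chloro in place of hydrogen on an aromatic carbon cannot be read. With 4-chlorophenoxy held constant, 2-nitro-1H-imidazol-1-yl in place of 3-nitro-1H-1,2,4-triazol-1-yl gives an at least 1.0-fold higher number from compound 1 to compound 3 (0.00 log units; that floor lies within the scatter), which is only a floor and sets no upper bound on the step.

The compounds shown leave open whether chloro has any effect at this place on the phenoxy ring. They also leave open whether a methoxy group or an amine there would give a value that is not a limit.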